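A methoxy to methyl swap at the assay limit

The source may report more compounds than this note shows. Statements on the series, on what has been measured and on what is new or still open speak of the compounds shown alone.

- compound 1 `COc1ccccc1CN1CCC=C(CCC(=O)NO)C1=O` gives > 10000 nM as a limit
- compound 2 `COc1cccc(CN2CCC=C(CCC(=O)NO)C2=O)c1` gives > 10000 nM as a limit
- compound 3 `O=C(CCC1=CCCN(CCCc2ccc(-c3ccccc3)cc2)C1=O)NO` gives 3230 nM as a number

All three compounds were read in a functional assay on PC-3 cells (Homo sapiens) for inhibition, read by sulforhodamine B assay (a lower number here means a stronger inhibitor of growth, a higher number a weaker inhibitor of growth), and only compound 3 returned a number. Compound 2 stands at a limit of the assay with > 10000 nM and has no measured number. Compound 1 also returned only a limit. Across the set, the results show the limit of > 10000 nM in this assay, at which 2 of the 3 values shown sit, and compound 2 is one of those two.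

Compound 4 `Cc1cccc(CN2CCC=C(CCC(=O)NO)C2=O)c1` keeps the core of compound 2 and carries methyl in place of methoxy on an aromatic carbon of a six-membered aromatic ring of carbon only, meta to a large group. Going by the values given here, no measured pair in the set shows this swap. The expectation therefore rests on compound 2 and its limit of > 10000 nM in this assay and it foresees no change beyond the scatter in either direction. The estimate is a step that the limit leaves unreadable from compound 2 to compound 4 as an expected step of no clear size. Compound 4 is expected near 12000 nM with an estimated range from 6000 nM to 25000 nM and quite possibly as a limit again.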

Compound 4, concentration for 50% growth inhibition: > 10000 nM
Compound 4: a limit, no number; the forecaster's own chance of this, stated with the estimate: 75%; the middle value lies beyond the limit too.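

In this assay compound 4 gives > 10000 nM as a limit and not a number. Going by these compounds alone, compound 2 likewise holds only a limit, so no step from compound 2 to compound 4 can be read: the limit of > 10000 nM in this assay, at which 3 of the 4 values shown sit. In this assay the compounds shown leave open whether methyl in place of methoxy on an aromatic carbon changes growth inhibition at all.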